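A few compounds are considered here, and "the series" means these few. Any claim that something is new, unique, unknown or untested is made for them only; others in the source may bear on it.

Compounds measured:
Compound 1, `C=C[C@@]1(O)[C@@H](CO)O[C@@H](n2ccc(N)nc2=O)[C@@H]1O`: 74300 nM
Compound 2, `C#C[C@]1(O)[C@H](O)[C@@H](CO)O[C@H]1n1ccc(N)nc1=O`: > 350000 nM (a limit)

Both compounds share a cytidine-like core with a substituent on a saturated ring carbon of the five-membered ring. Within the data shown here, in a functional assay on KB cells (Homo sapiens), read by MTT assay (on this read-out higher numbers stand for weaker inhibition and lower numbers for stronger inhibition), compound 1 gives 74300 nM, the only plain number among the two values shown. For compound 2 this assay reports only a limit, > 350000 nM, and not a number; the limit of > 350000 nM in this assay, at which 1 of the 2 values shown sits, marks where this one value sits. Among the measured compounds shown here, no measured step between compounds differing in a single place is available, so the size of the change from a vinyl to a triple-bonded group cannot be read from the data; the two values show only that compound 1 yields a number while compound 2 yields a limit.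

Compound 3, `CC#C[C@@]1(O)[C@@H](CO)O[C@@H](n2ccc(N)nc2=O)[C@@H]1O`, differs from compound 1 by prop-1-yn-1-yl in place of vinyl on a saturated ring carbon. The expected step is a 2.7-fold higher number from compound 1 to compound 3 (0.43 log units; beyond the scatter), toward weaker inhibition and likely beyond the usual scatter, with a real chance that only a limit is reported. Compound 3 is estimated at 200000 nM, within a range from 60000 nM to 700000 nM.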

Compound 3, half-maximal inhibitory concentration: 14600 nM
Compound 3: the middle estimate sits 14-fold (1.14 log units) above what was measured, outside the stated range (below it).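

Putting prop-1-yn-1-yl in place of vinyl on this saturated ring carbon gives a 5.1-fold lower number from compound 1 to compound 3 (0.71 log units; beyond the scatter) in this assay, a move toward stronger inhibition. Among these compounds, until now no pair of compounds differed in one place, so this is the first step that can be read, and it shows that the number at this position depends on which carbon group sits there. The group can also change from one with a double bond to a longer one with a triple bond without the read-out being lost, as compound 3 gives a plain number of 14600 nM.

On these data alone, a single step cannot tell whether the triple bond or the added carbon carries the change, and it remains open whether a saturated ethyl group, a longer chain such as but-1-yn-1-yl or an amine at this place would push the number further down or back up. The compounds shown also give no explanation for why the number falls with this change.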